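Series notes: aryl sulfonates with a cyclic urea nitrogen substituent

The compounds below may be only part of what the source reports. "The series", "measured", "known", "first", "only" and "open" are said of these compounds alone.

Measured so far in a functional assay on HT-29 cells (Homo sapiens) for antiproliferative activity, read by sulforhodamine B assay, with a stated time of 48 h; a lower number here means a stronger inhibitor, a higher number a weaker inhibitor:
compound 1, `Cc1ccccc1OS(=O)(=O)c1ccc(N2CCN(C)C2=O)cc1`, 4800 nM;
compound 2, `CCN1CCN(c2ccc(S(=O)(=O)Oc3cccc(F)c3)cc2)C1=O`, > 100000 nM;
compound 3, `CCCN1CCN(c2ccc(S(=O)(=O)Oc3ccccc3C)cc2)C1=O`, > 100000 nM.

Compound 1 is the only one of the three with a number. For compound 2 the value is a limit of this assay and not a number. For compound 3 the value is likewise a limit of this assay, so compound 3 stands only at the weak end of what the series shows so far; (the limit of > 100000 nM in this assay, at which 2 of the 3 values shown sit).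

For the measured compounds named here, the one step that can be counted, an at least 20-fold higher number from compound 1 to compound 3 (1.31 log units; beyond the scatter), carries compound 1 to that limit. It changes the chain on the urea nitrogen, not the phenyl ester, so it does not speak directly to the next change.

Compound 4, `CCCN1CCN(c2ccc(S(=O)(=O)Oc3ccc(C)cc3)cc2)C1=O`, differs from compound 3 only in the phenyl ester: 4-methylphenyl in place of 2-methylphenyl on an oxygen. Going by the values given here, no measured pair isolates this change, so there is no step to lean on. With compound 3 already at the limit, and compound 2 there as well, the expectation for compound 4 is that the shift a number no higher from compound 3 to compound 4 (the limit leaves the size open) is none beyond the scatter and that the assay again reports a limit. Compound 4 is therefore estimated at 100000 nM, with a range from 30000 nM to 300000 nM.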

Compound 4, half-maximal inhibitory concentration: 25000 nM
Compound 4: middle estimate off by 4.0-fold (0.60 log units), on the high side; measured number outside the range, below it.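

In this assay, 4-methylphenyl in place of 2-methylphenyl on the oxygen bound to the sulfonyl sulfur gives an at least 4.0-fold lower number from compound 3 to compound 4 (0.60 log units; beyond the scatter), so the phenyl ester is a place where the same atoms, joined differently, change the read-out. For the compounds shown here, the only step countable earlier altered the chain on the urea nitrogen; compound 4 keeps the chain of compound 3 and still gives a number, so that chain alone does not hold a compound at the limit. The value of compound 3 is a limit and not a number, so this step fixes only the smallest possible size of the change: the limit of > 100000 nM in this assay, at which 2 of the 4 values shown sit.

Whether 4-methylphenyl would lower the number in the same way with the shorter chains on the urea nitrogen of compound 1 and compound 2 stays open, since no pair shown isolates that change on either chain. Also open, on these data alone, is how the series responds to other groups on the phenyl ester, such as methoxy or chlorine, and to a longer chain such as butyl on the urea nitrogen.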